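A Phenyl Swap on a Low-Toxicity Core

The compounds below may be only part of what the source reports. "The series", "measured", "known", "first", "only" and "open" are said of these compounds alone.

The question in this small set is whether the compounds harm human liver-derived cells, measured in an ADME assay on Huh-7 cells (Homo sapiens) for cytotoxicity, with a stated time of 72 h; on this read-out lower numbers stand for higher toxicity in this test and higher numbers for lower toxicity in this test. Compound 1, with the structure `CS(=O)(=O)Nc1ccc2c(c1)S(=O)(=O)N=C(C1=C(O)C3CCCC3N(Cc3ccc(F)cn3)C1=O)N2`, gives in this assay only a limit of > 33000 nM, meaning no toxicity was reached within the tested range. A sibling, compound 2 `CS(=O)(=O)Nc1ccc2c(c1)S(=O)(=O)N=C(C1=C(O)[C@H]3CCC[C@H]3N(Cc3ccc(F)c(F)c3)C1=O)N2`, also gives only a limit in this assay, > 1000 nM. Both results therefore place the shared core among compounds of low toxicity in this test, with compound 1 at the limit described as the limit of > 33000 nM in this assay, at which 1 of the 2 values shown sits.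

Compound 3, with the structure `CS(=O)(=O)Nc1ccc2c(c1)S(=O)(=O)N=C(C1=C(O)C3CCCC3N(Cc3ccccc3)C1=O)N2`, has not yet been tested. It differs from compound 1 by the change (phenyl in place of 5-fluoropyridin-2-yl on a saturated chain carbon bound to an amide-type nitrogen in a ring). For the measured compounds named here, with no measured step available between related pairs, the expectation is no step beyond the usual scatter, a number no higher from compound 1 to compound 3 (the limit leaves the size open), and most likely again a limit. Compound 3 is thus expected at about 33000 nM, within a range from 10000 nM to 100000 nM.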

Compound 3, half-maximal cytotoxic concentration: > 33000 nM
Compound 3: a limit, no number; the forecaster's own chance of this, stated with the estimate: 80%; the middle value lies on the limit itself.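

Compound 1 and compound 3 both give only a limit in this assay, and no step can be read between them. Left open is the concentration at which either compound would harm these cells, and whether phenyl in place of 5-fluoropyridin-2-yl changes it at all.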